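Removing the methoxy group from compound 2

This account rests on a few compounds, and the source may have more. Where it says the series, first, only, none or still open, it means among the compounds named here.

Compound 1 `CCCSc1nc(N/N=C(\C)c2ccc(O)cc2)c2nnn(Cc3ccccc3)c2n1`: 21600 nM
Compound 2 `CCCSc1nc(N/N=C(\C)c2ccc(OC)cc2)c2nnn(Cc3ccccc3)c2n1`: > 64000 nM

Both compounds were tested in a functional assay on MCF7 cells (Homo sapiens) for antiproliferative activity, read by MTT assay, with a stated time of 72 h; on this read-out lower numbers stand for stronger inhibition and higher numbers for weaker inhibition. Compound 2 stands at > 64000 nM, which is a limit and not a number. No exact potency can therefore be read for it, only (the limit of > 64000 nM in this assay, at which 1 of the 2 values shown sits).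

The next compound, compound 3 `CCCSc1nc(N/N=C(\C)c2ccccc2)c2nnn(Cc3ccccc3)c2n1`, has hydrogen in place of methoxy on an aromatic carbon, para to a large group (hydrogen in place of methoxy on an aromatic carbon). For the measured compounds named here, one measured step bears on this change: an at least 2.9-fold higher number from compound 1 to compound 2 (0.47 log units; beyond the scatter). There, methyl took the place of hydrogen on an oxygen on an aromatic ring, and the step lies beyond the scatter. It is only a minimum, so it gives a direction better than it gives a size.

Compound 3 lacks that methyl too, as does compound 1 at 21600 nM, so a modest move to a lower number is expected in this assay. The expected step is an at least 1.6-fold lower number from compound 2 to compound 3 (0.20 log units; that floor lies within the scatter). Compound 3 is estimated at 40000 nM, with an expected range of 17000 nM to 64000 nM.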

Compound 3, half-maximal inhibitory concentration: 32100 nM
The estimate for compound 3 lay 1.2-fold (0.10 log units) above the measured number; the range from low to high includes it.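

The new compound shows that the hydroxy group of compound 1 is not needed at this position: with hydrogen in its place, this assay gives a 1.5-fold higher number from compound 1 to compound 3 (0.17 log units; within the scatter), so the two compounds cannot be told apart. Taking the methoxy group away gives an at least 1.9-fold lower number from compound 2 to compound 3 (0.29 log units; that floor lies within the scatter), and although that floor lies within the scatter, it points the same way as the earlier step from hydroxy to methoxy, so among these three groups only methoxy may stand apart from the other two. Compound 2 has a limit and not a number, so the full size of this step stays unknown: the limit of > 64000 nM in this assay, at which 1 of the 3 values shown sits.

These three compounds cannot tell why methoxy differs from hydroxy and hydrogen, or whether a larger ether such as ethoxy would behave like methoxy. Nor do they show what an amine, a chlorine atom or a carboxylic acid would do at this position, or whether any group placed here could bring the number well below those of compound 1 and compound 3.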